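Thiophen-3-yl in place of 4-sulfamoylphenyl: half-life expected

The compounds below may be only part of what the source reports. "The series", "measured", "known", "first", "only" and "open" are said of these compounds alone.

- Compound 1 `N#Cc1ccc(F)cc1Cn1c(N2CCC[C@@H](N)C2)nc2c(-c3cccs3)c[nH]c2c1=O` with 0.585 h as measured
- Compound 2 `N#Cc1ccc(F)cc1Cn1c(N2CCC[C@@H](N)C2)nc2c(-c3ccc(S(N)(=O)=O)cc3)c[nH]c2c1=O` with > 3.33 h as a limit

Both entries come from an ADME assay on microsomes from liver (Homo sapiens) for metabolic stability, read by LC-MS, tested at 1 mM (a lower number here means that the compound disappears faster, a higher number that the compound lasts longer), as the read-out. Compound 2 has only the limit of > 3.33 h in this assay, at which 1 of the 2 values shown sits, and no exact number.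

Compound 3 `N#Cc1ccc(F)cc1Cn1c(N2CCC[C@@H](N)C2)nc2c(-c3ccsc3)c[nH]c2c1=O` carries thiophen-3-yl in place of 4-sulfamoylphenyl on an aromatic carbon, counted as thiophen-3-yl in place of 4-sulfamoylphenyl on an aromatic carbon in the comparison. Within the data shown here, one measured step bears on this change, and it runs the other way: an at least 5.6-fold higher number from compound 1 to compound 2 (0.75 log units; beyond the scatter) with 4-sulfamoylphenyl replacing thiophen-2-yl. Its true size is open, as it ends at a limit. A fall of similar size is expected in this assay for the return to a thiophenyl group, and the step is estimated as an at least 4.7-fold lower number from compound 2 to compound 3 (0.67 log units; beyond the scatter) in all. For compound 3 the estimated half-life is 0.7 h with an expected range of 0.3 h to 1.6 h for now.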

Compound 3, half-life: 2.67 h
Beside the measured number, compound 3's estimate is 3.8-fold (0.58 log units) below it, outside the stated range (above it).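

In this assay, thiophen-3-yl in place of thiophen-2-yl gives a 4.6-fold higher number from compound 1 to compound 3 (0.66 log units; beyond the scatter), so at this position the outcome depends on which thiophenyl group is attached, not merely on the presence of a thiophene ring. Thiophen-3-yl in place of 4-sulfamoylphenyl gives an at least 1.2-fold lower number from compound 2 to compound 3 (0.09 log units; that floor lies within the scatter), so a half-life well beyond that of compound 1 does not require the 4-sulfamoylphenyl group. The true size of this second step stays open because compound 2 is known only through a limit: the limit of > 3.33 h in this assay, at which 1 of the 3 values shown sits.

A plain phenyl ring on this carbon would show how much of the 4-sulfamoylphenyl result depends on the sulfonamide, and a pyridyl ring would extend the comparison to another aromatic group. Also open, going by these compounds, is whether a methyl group or chlorine on the thiophene ring changes the half-life.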